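Aminoquinoline series: methylamino for dimethylamino, cytotoxicity

The source may report more compounds than this note shows. Statements on the series, on what has been measured and on what is new or still open speak of the compounds shown alone.

Compound 1 `CN(C)c1ccc2cc(-c3cc(Cl)cc(Cl)c3)c(N)nc2c1` and compound 3 `CNc1ccc2cc(-c3cc(Cl)cc(Cl)c3)c(N)nc2c1` share a core; compound 2 `CN(C)c1ccc2cc(-c3cn(C)c4ccccc34)c(N)nc2c1` and compound 4 `CNc1ccc2cc(-c3cn(C)c4ccccc34)c(N)nc2c1` share another. How the two cores differ is not broken down here. In a toxicity assay on J774.A1 cells (Mus musculus) for cytotoxicity, read by SYBR Green assay, with a stated time of 1 h (on this read-out lower numbers stand for an effect already at smaller amounts and higher numbers for an effect only at larger amounts of compound), compound 1 gives 3700 nM, and compound 3 gives 3700 nM. Compound 2 gives 3700 nM in this assay, level with compound 1 and compound 3. The change from compound 1 to compound 3 is hydrogen in place of methyl on a nitrogen on an aromatic ring, and it made the step of no change at the digits printed from compound 1 to compound 3 (within the scatter). The same change, (hydrogen in place of methyl on a nitrogen on an aromatic ring), turns compound 2 into compound 4. Because the step of no change at the digits printed from compound 1 to compound 3 (within the scatter) stayed within the scatter, the step from compound 2 to compound 4 is expected to be of the same size, no change at the digits printed from compound 2 to compound 4 (within the scatter). Compound 4 is therefore estimated at 3700 nM in this assay, between 1800 nM and 7500 nM.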

Compound 4, half-maximal effective concentration: 4100 nM
For compound 4 the middle estimate is 1.1-fold (0.04 log units) below the measured one; the measured number falls inside the stated range.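

In this assay, the exchange of dimethylamino for methylamino gives a 1.1-fold higher number from compound 2 to compound 4 (0.04 log units; within the scatter). The change carries across the two cores shown without a readable difference: the same change on two cores in this assay, no change at the digits printed (within the scatter) from compound 1 to compound 3 and a 1.1-fold higher number (0.04 log units; within the scatter) from compound 2 to compound 4, 1.1-fold (0.04 log units) apart, within the scatter of two such steps

This agreement rests on just two steps, both within the scatter, and covers only this cytotoxicity read-out; it does not show that the change would remain without effect on other cores, and it gives no reason for the flat result.

Still open, going by these compounds, is whether the same nitrogen tolerates a longer chain, such as ethyl or propyl, in place of methyl. Also open, on these data alone, is whether a core carrying a carboxylic acid would give a step of the same size.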